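The source may hold more compounds than are shown below. What is called first, only, known or untested is meant among the compounds shown, and "the series" means these compounds.

Measured so far:
- compound 1 `CC1=C(C(=O)OCC(F)(F)F)C(c2ccsc2)NC(=O)N1`: 2% in an assay on cells for displacement of a labelled ligand from adenosine receptor A1 (Homo sapiens), read by radioligand binding, with a stated time of 60 min, tested at 1 uM; on this read-out lower numbers stand for less inhibition and higher numbers for more inhibition at the one concentration tested (going by the name of the read-out)
- compound 2 `CC1=C(C(=O)OCC(F)(F)F)C(c2cccs2)NC(=O)N1`: 3% in this assay

Both compounds share one core and differ only in the five-membered ring that hangs from a saturated ring carbon. In this assay compound 1 gives 2%, and compound 2 gives 3%. Going by the values given here, the one step seen so far, a number 1 percentage points higher from compound 1 to compound 2 (within the scatter), is too small to tell the two apart, so compound 2 cannot be said to stand apart from compound 1 on these numbers; both show very little displacement of the labelled ligand at the single concentration tested.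

Compound 3 `CC1=C(C(=O)OCC(F)(F)F)C(c2ccco2)NC(=O)N1` has not yet been measured. It differs from compound 2 by furan-2-yl in place of thiophen-2-yl on a saturated ring carbon. Among the compounds with values here, the only step that bears on this change is the swap of one five-membered ring for another between compound 1 and compound 2, which left the read-out essentially unchanged. A second swap of the same kind, again exchanging one ring hetero atom for another, is therefore expected to give no step beyond the scatter, and the step of no change at the digits printed from compound 2 to compound 3 (within the scatter) is estimated accordingly. Compound 3 is expected to give about 3% in this assay, with a likely range from -5% to 12%.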

Compound 3, a percentage reported as inhibition, at one concentration (the size of the read-out at that concentration, not a potency): 10%
For compound 3 the middle estimate is 7 percentage points below the measured one; low and high end bracket the measured number.
By their numbers in this assay, from the lowest: compounds 1, 2 and 3 (each within the scatter of the next).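

Placing furan-2-yl in the position of thiophen-2-yl on this saturated ring carbon gives, in this assay, a number 7 percentage points higher from compound 2 to compound 3 (within the scatter), and placing it in the position of thiophen-3-yl gives a number 8 percentage points higher from compound 1 to compound 3 (within the scatter). Both steps stay inside the scatter, so a ring oxygen in place of a ring sulfur gives no readable change here, and the three five-membered aromatic rings cannot be told apart at this position, even though compound 3 has the largest printed number. No measurement is available that could explain the size of these small steps or tie them to any property of the rings.

All three compounds carry a five-membered aromatic ring with a single hetero atom, so the compounds shown leave open how this read-out would respond to a phenyl ring, a pyridine ring or a group carrying an amine or a carboxylic acid on the same carbon. They also leave open whether a change elsewhere on the shared core, such as a different chain on the ester in place of the trifluoroethyl group, would lift the displacement clearly beyond the scatter.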